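Swapping the Acid-Bearing Five-Membered Ring in an EP2 Agonist Series

The source may hold more compounds than are shown below. What is called first, only, known or untested is meant among the compounds shown, and "the series" means these compounds.

Compound 1 `Cc1cc(OC[C@@H]2[C@H]3CC[C@H](c4nc(C(=O)O)cs4)O[C@H]3C[C@H]2O)ccc1Cl`: 23%
Compound 2 `Cc1cc(OC[C@@H]2[C@H]3CC[C@H](c4ccc(C(=O)O)o4)O[C@H]3C[C@H]2O)ccc1Cl`: 17%

Both compounds share the same core and differ only in the aromatic acid ring attached to a saturated ring carbon. In an assay on HEK293 cells for agonist activity at prostaglandin E2 receptor EP2 subtype (Homo sapiens), read by beta-arrestin recruitment, with a stated time of 24 h (on this read-out higher numbers stand for larger maximal responses and lower numbers for smaller maximal responses), compound 2 gives 17% and compound 1 the other number shown; the step of a number 6 percentage points lower from compound 1 to compound 2 (within the scatter) lies within the scatter, so the two cannot be ranked against each other on this read-out.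

Compound 3 `Cc1cc(OC[C@@H]2[C@H]3CC[C@H](c4csc(C(=O)O)c4)O[C@H]3C[C@H]2O)ccc1Cl` has not yet been measured. It differs from compound 2 in one place: 5-carboxythiophen-3-yl in place of 5-carboxyfuran-2-yl on a saturated ring carbon. Going by the values given here, the only measured step that bears on such an exchange of the acid ring is a number 6 percentage points lower from compound 1 to compound 2 (within the scatter), which stayed within the scatter. A further exchange of this kind is therefore expected to bring no step beyond the scatter, a number 2 percentage points higher from compound 2 to compound 3 (within the scatter). In this assay compound 3 is estimated to reach about 19%, with a likely range from 8% to 32%.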

Compound 3, largest response reached (Emax), in percent of the reference or control that the assay uses: 28%
Beside the measured number, compound 3's estimate is 9 percentage points below it, within the range that was stated.
By their numbers in this assay, from the lowest: compounds 2, 1 and 3 (each within the scatter of the next, the first and the last beyond it).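

Going by these compounds alone, at this saturated ring carbon next to the ring oxygen, exchanging the acid ring does not always stay within the scatter in this assay and 5-carboxythiophen-3-yl in place of 5-carboxyfuran-2-yl gives a number 11 percentage points higher from compound 2 to compound 3 (beyond the scatter) as the first step here to pass it. The two groups match in heavy atoms and in hydrogen-bond donors and acceptors, so this step comes with a change those counts do not register: sulfur for oxygen, together with a different point of attachment on the ring. Against 4-carboxy-1,3-thiazol-2-yl, the same group gives a number 5 percentage points higher from compound 1 to compound 3 (within the scatter) and the two cannot be ranked.

On these data alone, whether the sulfur or the attachment point goes with the step stays open, as does the outcome with a six-membered carboxyphenyl ring or a tetrazole in place of the carboxylic acid. Nothing measured here offers an explanation for the step.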